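Swapping a trifluoromethoxy group for a pyrimidine ring

The compounds below may be only part of what the source reports. "The series", "measured", "known", "first", "only" and "open" are said of these compounds alone.

Measured compounds:
compound 1 `COc1cccc(OC)c1C1CCCC(=O)N1c1ccccc1`, > 10000 nM
compound 2 `COc1cccc(OC)c1C1CCCC(=O)N1Cc1cccc(OC(F)(F)F)c1`, 94 nM
compound 3 `COc1cccc(OC)c1C1CCCC(=O)N1Cc1ccc(-c2ccccc2)cc1`, 72 nM

Three compounds sharing one core were tested in a functional assay on CHO cells for antagonist activity at Orexin receptor type 2 (Homo sapiens), read by FLIPR and calcium flux; a higher number here means a weaker inhibitor, a lower number a stronger inhibitor. For compound 1 this assay gives only a limit, > 10000 nM, so no number is known for it. Compound 2 gives 94 nM, and compound 3, which also carries a second aromatic ring, gives 72 nM; these two numbers lie within the usual scatter of each other, so neither can be called the stronger.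

Compound 4 `COc1cccc(OC)c1C1CCCC(=O)N1Cc1cccc(-c2ncccn2)c1` has not been measured. It differs from compound 2 in one place: pyrimidin-2-yl in place of trifluoromethoxy on an aromatic carbon. Among the compounds with values here, no measured pair shows this change directly. Since compound 3 shows 72 nM with an added aromatic ring, the step of a 1.6-fold lower number from compound 2 to compound 4 (0.19 log units; within the scatter) is expected to stay within the scatter. Compound 4 is therefore expected to give about 60 nM, plausibly between 15 nM and 250 nM.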

Compound 4, half-maximal inhibitory concentration: 28 nM
For compound 4 the middle estimate is 2.1-fold (0.33 log units) above the measured one; measured number inside the range.
By their numbers in this assay, from the lowest: compound 4; then compounds 3 and 2 (each within the scatter of the next). At a limit, above all of these: compound 1.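

Within the data shown here, this is the first change made at a single place, and it gives a 3.4-fold lower number from compound 2 to compound 4 (0.53 log units; beyond the scatter). On this aromatic carbon, meta to a large group, pyrimidin-2-yl is therefore more than tolerated in place of trifluoromethoxy, with a modest gain in inhibition. Nothing measured here accounts for that gain. Still open, as far as these compounds go, is how a plain phenyl ring, an amine or a carboxylic acid on this same carbon would compare. So is whether the gain depends on the nitrogen atoms of the pyrimidin-2-yl ring.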